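The source may report more compounds than this note shows. Statements on the series, on what has been measured and on what is new or still open speak of the compounds shown alone.

Working notes on the series. In an assay on CHO cells for displacement of a labelled ligand from adenosine receptor A1 (Homo sapiens), read by scintillation counting, with a stated time of 90 min (a lower number here means a stronger inhibitor, a higher number a weaker inhibitor), compound 1 `Nc1nc(NCc2ccco2)nc2sc(-c3ccco3)nc12` gives 38 nM. Compound 2 `Nc1nc(NCc2ccccn2)nc2sc(-c3ccco3)nc12` gives 28 nM in this assay, and compound 3 `COc1cccc(CNc2nc(N)c3nc(-c4cccs4)sc3n2)c1` gives 37 nM. The three numbers lie within the scatter of one another, so compound 1 stands level with both of the others on the numbers shown.

Compound 4 `Nc1nc(NCc2cnccn2)nc2sc(-c3ccco3)nc12` differs from compound 1 in one place: pyrazin-2-yl in place of furan-2-yl on a saturated chain carbon bound to a nitrogen on an aromatic ring. Among the measured compounds shown here, the one measured step that bears on this exchange is a 1.4-fold lower number from compound 1 to compound 2 (0.13 log units; within the scatter), where a six-membered aromatic ring with one ring nitrogen took the place of the same furan-2-yl group at the same position and the number stayed within the scatter. For the measured compounds named here, compound 4 carries a six-membered aromatic ring with two ring nitrogens at that position; no measured pair speaks to the second nitrogen, so the step from compound 2 is taken as the nearest guide. The expectation for compound 4 in this assay is therefore no step beyond the scatter, a 1.2-fold lower number from compound 1 to compound 4 (0.07 log units; within the scatter). Compound 4 is estimated at 32 nM, with a range from 15 nM to 70 nM.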

Compound 4, inhibition constant: 25 nM
Compound 4: middle estimate off by 1.3-fold (0.11 log units), on the high side, within the range that was stated.
By their numbers in this assay, from the lowest: compounds 4, 2, 3 and 1 (each within the scatter of the next).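

In this assay the exchange of furan-2-yl for pyrazin-2-yl on a saturated chain carbon bound to a nitrogen on an aromatic ring gives a 1.5-fold lower number from compound 1 to compound 4 (0.18 log units; within the scatter) and so adds a second six-membered aromatic ring to those this place accepts with no step beyond the scatter. The second ring nitrogen now has a measured step of its own, a 1.1-fold lower number from compound 2 to compound 4 (0.05 log units; within the scatter), and pyrazin-2-yl and pyridin-2-yl stand level here. Nothing measured on these compounds accounts for the three groups standing level.

All the groups shown at this place in the furan-2-yl series are aromatic rings, so it remains open whether the numbers hold with a cyclohexyl group, a tertiary amine or a carboxylic acid there. From the compounds shown here alone, a longer chain in place of the methyl link of (pyrazin-2-yl)methyl is equally open.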